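The compounds below may be only part of what the source reports. "The series", "measured", "known", "first", "only" and "open" are said of these compounds alone.

Measured so far in a physicochemical assay for solubility, in phosphate buffer, at pH 7.4 (a higher number here means a more soluble compound, a lower number a less soluble compound), each value being a limit of the assay:
- compound 1 `CCOC(=O)c1c(-c2ccc(OC)cc2)[nH]c2cccc(OC)c2c1=O` gives > 100000 nM
- compound 2 `CCOC(=O)c1c(-c2ccc(Cl)cc2)[nH]c2cccc(OC)c2c1=O` gives > 100000 nM
- compound 3 `CCOC(=O)c1c(-c2ccccc2)[nH]c2cccc(OC)c2c1=O` gives > 100000 nM

Compound 3 gives > 100000 nM and this is a limit, not a number. That is the limit of > 100000 nM in this assay, at which 3 of the 3 values shown sit, so its true standing cannot be read.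

Compound 4 `CCOC(=O)c1c(-c2ccccc2Cl)[nH]c2cccc(OC)c2c1=O` turns the phenyl of compound 3 into 2-chlorophenyl chloro in place of hydrogen on an aromatic carbon on an aromatic carbon.

The closest measured change is a step that the two limits leave unreadable from compound 2 to compound 3 with hydrogen in place of chloro, while a step that the two limits leave unreadable from compound 1 to compound 2 and a step that the two limits leave unreadable from compound 1 to compound 3 add no size either. With no readable size to carry over, no step beyond the scatter is expected in this assay and no direction. The estimate therefore means a number no higher from compound 3 to compound 4 (the limit leaves the size open) as the expected step. Compound 4 is expected at 100000 nM with an estimated range of 50000 nM to 200000 nM as its likely span.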

Compound 4, solubility: > 100000 nM
Compound 4: only a limit was reported; the forecaster's own chance of this, stated with the estimate: 80%; the middle value sits exactly at the limit.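

In this assay compound 4 gives > 100000 nM as a limit, so its steps to compound 1, compound 2 and compound 3 cannot be read: the limit of > 100000 nM in this assay, at which 4 of the 4 values shown sit. On these data alone, how far these four compounds truly differ in this assay stays open.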